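A few compounds are considered here, and "the series" means these few. Any claim that something is new, unique, unknown or untested is made for them only; others in the source may bear on it.

Measured so far:
compound 1 `CN(C(=O)CCCCCCCSc1nnc(Cc2nn(C)c(=O)c3ccccc23)n1C)c1ccc(Cl)cc1Cl` gives 11900 nM in an assay on isolated protein (Mus musculus) for inhibition of IL15-IL15 receptor (Homo sapiens), read by resazurin assay, with stated times of 30 min and 2.5 days; a lower number here means a stronger inhibitor, a higher number a weaker inhibitor;
compound 2 `Cn1c(Cc2nn(C)c(=O)c3ccccc23)nnc1SCCCCCCCC(=O)Nc1ccc(O)cc1O` gives 17000 nM in this assay.

Going by the values given here, compound 2 stands alongside compound 1 rather than apart from it: the only step, a 1.4-fold higher number from compound 1 to compound 2 (0.15 log units; within the scatter), lies within the scatter, so the two compounds cannot be told apart on these numbers. Compound 3 `Cn1c(Cc2nn(C)c(=O)c3ccccc23)nnc1SCCCCCCCC(=O)Nc1ccc(Cl)cc1` has not yet been measured. It differs from compound 2 in one place: 4-chlorophenyl in place of 2,4-dihydroxyphenyl on an amide-type nitrogen. Among the compounds with values here, the one measured step that bears on this part of the molecule is a 1.4-fold higher number from compound 1 to compound 2 (0.15 log units; within the scatter), which exchanged a chlorinated, methylated amino group for a dihydroxylated one and moved the number by no more than the scatter. Compound 3 again carries a chlorinated ring on the amide-type nitrogen, and on that single comparison the expected step of a 1.3-fold lower number from compound 2 to compound 3 (0.12 log units; within the scatter) is small, in no clear direction. Compound 3 is therefore estimated at 13000 nM, with a range from 5000 nM to 35000 nM.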

Compound 3, half-maximal inhibitory concentration: 800 nM
Estimate against measurement, compound 3: 16-fold (1.21 log units) above; the whole stated range lies above it.
By their numbers in this assay, from the lowest: compound 3; then compounds 1 and 2 (each within the scatter of the next).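

Going by these compounds alone, the group on the amide-type nitrogen matters far more than the only earlier step suggested: in this assay, 4-chlorophenyl in place of 2,4-dihydroxyphenyl gives a 21-fold lower number from compound 2 to compound 3 (1.33 log units; beyond the scatter) and marks this as a sensitive position. Having chlorine on the ring is not enough by itself, since (4-chlorophenyl)amino in place of (2,4-dichlorophenyl)(methyl)amino gives a 15-fold lower number from compound 1 to compound 3 (1.17 log units; beyond the scatter) even though both rings carry chlorine. Within the data shown here, nothing measured here explains why either change moves the number so far.

The compounds shown do not separate the extra chlorine from the methyl on the nitrogen, as the two change together in that last step. They also leave open how a plain phenyl, a 4-fluorophenyl or a 4-methoxyphenyl ring would compare with 4-chlorophenyl in this assay on this chain.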